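Adding a (Diethylcarbamoyl)methyl Arm to a Weak Cytotoxic Series

The compounds below may be only part of what the source reports. "The series", "measured", "known", "first", "only" and "open" are said of these compounds alone.

Compound 1 `COc1ccc(-c2cc3cccc(OC)c3nc2O)cc1`: 10000 nM
Compound 2 `COc1cc(OC)c2cc(-c3ccc(OCc4ccccc4)cc3)c(O)nc2c1`: 10000 nM
Compound 3 `COc1ccc(-c2cc3c(OC)cc(OC)cc3n(C)c2=O)cc1`: 10000 nM

Of the compounds shown here, three have been tested in a functional assay on J82 cells (Homo sapiens) for cytotoxicity, read by colorimetric assay and MTT assay; a higher number here means a weaker inhibitor, a lower number a stronger inhibitor. In this assay compound 1 gives 10000 nM, compound 2 gives 10000 nM and compound 3 gives 10000 nM. Compound 3 therefore stands level with compounds 1 and 2: the differences among the three are within the scatter, so no order can be read from them, and none of them is a strong inhibitor.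

Compound 4 `CCN(CC)C(=O)CCn1c(=O)c(-c2ccc(OC)cc2)cc2c(OC)cc(OC)cc21` is built from compound 3 by one change: (diethylcarbamoyl)methyl in place of hydrogen on a saturated chain carbon bound to an aromatic nitrogen. For the measured compounds named here, nothing measured so far tells what such an addition does, since no pair of measured compounds differs in this way. With all three measured values sitting at the same weak level, the expectation for the step from compound 3 to compound 4 is none beyond the scatter, that is no change at the digits printed from compound 3 to compound 4 (within the scatter). Compound 4 is thus expected to give about 10000 nM in this assay, within a range from 3000 nM to 30000 nM.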

Compound 4, half-maximal inhibitory concentration: 10000 nM
Compound 4: the middle estimate sits on the measured number at the digits printed; the measured number falls inside the stated range.
By their numbers in this assay, from the lowest: compounds 1, 2, 3 and 4 (each within the scatter of the next).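

In this assay, for the compounds shown here, putting (diethylcarbamoyl)methyl in place of hydrogen on a saturated chain carbon bound to an aromatic nitrogen gives no change at the digits printed from compound 3 to compound 4 (within the scatter), the first reading of any change at this position. The position can therefore carry an arm of 8 heavy atoms, with an amide carbonyl and no ring, without the number moving, whereas compound 3 has only a methyl there. No other data bear on why this number holds.

Going by these compounds, whether a different end on this chain, such as a carboxylic acid or a simple amine, or a much longer chain, would move the number remains open. So does whether this arm would have the same outcome on a compound well below this weak level, since all the compounds here sit at the same value.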